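The source may hold more compounds than are shown below. What is called first, only, known or untested is meant among the compounds shown, and "the series" means these compounds.

Working notes on the series. Three compounds have numbers in an assay on cell membranes with adenosine receptor A1 (Rattus norvegicus) as the target (a lower number here means a stronger inhibitor, a higher number a weaker inhibitor), so far. Compound 1 `CC(C)Cn1c(=O)n(C)c(=O)c2c1ncn2C` gives 19000 nM in this assay. Compound 2 `C#CCn1cnc2c1c(=O)n(C)c(=O)n2C` gives 12000 nM in this assay, and compound 3 `C=CCn1c(=O)c2c(ncn2C)n(CC=C)c1=O` gives 18000 nM in this assay. Compound 1 carries the highest of the three numbers, yet its gaps to compound 3 and to compound 2 both sit within the scatter, so no order among the three can be drawn. Compound 4 `CCCn1cnc2c1c(=O)n(C)c(=O)n2CC(C)C` is not yet measured in this assay. Relative to compound 1 it differs by ethyl in place of hydrogen on a saturated chain carbon bound to an aromatic nitrogen. Going by the values given here, no measured pair shows this change, so the expected step from compound 1 to compound 4, a 1.3-fold lower number from compound 1 to compound 4 (0.10 log units; within the scatter), is taken as none beyond the scatter. Compound 4 is estimated at 15000 nM, with a range from 5000 nM to 45000 nM in this assay.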

Compound 4, inhibition constant: 13000 nM
For compound 4 the middle estimate is 1.2-fold (0.06 log units) above the measured one; the measured number falls inside the stated range.
By their numbers in this assay, from the lowest: compounds 2, 4, 3 and 1 (each within the scatter of the next).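

Going by these compounds alone, this is the first step that can be read at a single place: in this assay, ethyl in place of hydrogen on a saturated chain carbon bound to an aromatic nitrogen, or methyl to propyl when cut one bond further out, gives a 1.5-fold lower number from compound 1 to compound 4 (0.16 log units; within the scatter) and stays within the scatter. On this one pair, the propyl and methyl compounds cannot be told apart at this position. No measured evidence bears on this result. Still open, from the compounds shown here alone, is whether an amine, a carboxylic acid or a phenyl ring at this place would give a step beyond the scatter.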